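A few compounds are considered here, and "the series" means these few. Any claim that something is new, unique, unknown or untested is made for them only; others in the source may bear on it.

In a functional assay on HT-29 cells (Homo sapiens) for inhibition (a higher number here means a weaker inhibitor, a lower number a stronger inhibitor), compound 1 `COCCOc1cc(/C=C/c2ccc3ccccc3c2)ccc1OC` gives > 5000 nM, which is a limit of the assay and not a number. Compound 2 `COc1ccc(/C=C/c2ccc3ccccc3c2)cc1[N+](=O)[O-]` gives > 5000 nM, and this too is a limit. So compound 2 has no exact position on the scale, and the same is true of the only other compound measured. Among the measured compounds shown here, the one measured step, a step that the two limits leave unreadable from compound 1 to compound 2, offers no size to borrow, and the overall picture is the limit of > 5000 nM in this assay, at which 2 of the 2 values shown sit.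

Compound 3 `COc1ccc(/C=C/c2ccc3ccccc3c2)cc1N` carries amino in place of nitro on an aromatic carbon, ortho to a methoxy group: amino in place of nitro on an aromatic carbon. For the measured compounds named here, no measured step involves this change, so any expectation in this assay is loose. A large gain is not expected, though a modest shift towards stronger inhibition remains possible. The expected change is an at least 1.2-fold lower number from compound 2 to compound 3 (0.09 log units; that floor lies within the scatter). For compound 3 the estimated value is 4000 nM, with an expected range from 800 nM to 20000 nM.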

Compound 3, half-maximal inhibitory concentration: > 5000 nM
Compound 3 gave a limit, no number (the forecaster's own chance of this, stated with the estimate: 60%); at least 1.2-fold (0.09 log units) between middle value and limit.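

Among the compounds shown here, compound 3 gives > 5000 nM in this assay and this too is a limit and not a number, so no step among compound 1, compound 2 and compound 3 can be read. Still open is how strongly each compound inhibits, and whether nitro, amino or 2-methoxyethoxy makes any difference: the limit of > 5000 nM in this assay, at which 3 of the 3 values shown sit.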